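A few compounds are considered here, and "the series" means these few. Any claim that something is new, unique, unknown or untested is made for them only; others in the source may bear on it.

Of the compounds shown here, three of one family have so far been measured in an assay on HEK293 cells for agonist activity at transient receptor potential cation channel subfamily M member 8 (Homo sapiens), read by fluorescence and calcium flux, with a stated time of 15 min; on this read-out higher numbers stand for an effect only at larger amounts of compound and lower numbers for an effect already at smaller amounts. Compound 1 `Cc1ccc(OCC(=O)N(Cc2cccs2)CC(C)C)cc1` gives 900 nM in this assay, the highest of the three numbers. Compound 2 `CCN(Cc1ccco1)C(=O)COc1ccc(C)cc1` gives 489 nM in this assay, and its gap to compound 1 lies within the usual scatter, so the two are not separated. Compound 3 `CCN(Cc1cccs1)C(=O)COc1ccc(C)cc1O` gives 8 nM in this assay, far beyond the scatter from compound 1; compound 3 differs from compound 1 in more than one place, so no single change can be credited with that gap.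

Compound 4 `COCCN(Cc1cccs1)C(=O)COc1ccc(C)cc1` has not yet been measured. It differs from compound 1 in one place: methoxymethyl in place of isopropyl on a saturated chain carbon bound to an amide-type nitrogen. The leaving and entering groups carry the same count of heavy atoms, and the entering methoxymethyl brings one hydrogen-bond acceptor. Among the compounds with values here, no measured pair isolates this change, so its effect can only be estimated. The step of a 1.3-fold lower number from compound 1 to compound 4 (0.11 log units; within the scatter) is expected to stay within the scatter, with no clear direction. Compound 4 is therefore expected to give about 700 nM in this assay, with a likely range from 200 nM to 2500 nM.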

Compound 4, half-maximal effective concentration: 400 nM
Compound 4: the middle estimate sits 1.8-fold (0.24 log units) above what was measured; measured number inside the range.
By their numbers in this assay, from the lowest: compound 3; then compounds 4, 2 and 1 (each within the scatter of the next, the first and the last beyond it).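

Within the data shown here, the swap of isopropyl for methoxymethyl on a saturated chain carbon bound to an amide-type nitrogen is the first change in this family that can be read on its own, and it gives a 2.3-fold lower number from compound 1 to compound 4 (0.35 log units; beyond the scatter) in this assay. Read one bond further out as isobutyl to 2-methoxyethyl, it shows that this position accepts an oxygen and a hydrogen-bond acceptor at the same heavy-atom count without the number rising, though the step is modest. Nothing measured here explains the step.

On these data alone, whether a 2-hydroxyethyl group, a 2-aminoethyl group or a longer methoxy-bearing chain would move the number further at this position remains open. So does whether the same swap would have a similar effect on the core of compound 3.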